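Swapping Bromo for Butoxy on a Dioxygenase Inhibitor

The source may hold more compounds than are shown below. What is called first, only, known or untested is meant among the compounds shown, and "the series" means these compounds.

Compound 1 `O/N=C(/Nc1cccc(Br)c1)c1ccc2occc2c1` is the strongest of the three compounds measured in an assay on isolated protein for inhibition of Indoleamine 2,3-dioxygenase 1 (Homo sapiens), read by spectrophotometry (a higher number here means a weaker inhibitor, a lower number a stronger inhibitor), where compound 1 gives 440 nM. Compound 3 `O/N=C(/Nc1ccc(F)c(Br)c1)c1ccc2occc2c1` gives 1600 nM in this assay, and compound 2 `O/N=C(/Nc1ccc(F)c(F)c1)c1ccc2occc2c1` gives 22700 nM. Two steps connect them: a 3.6-fold higher number from compound 1 to compound 3 (0.56 log units; beyond the scatter), and a 14-fold lower number from compound 2 to compound 3 (1.15 log units; beyond the scatter). Compound 4 `CCCCOc1cccc(N/C(=N/O)c2ccc3occc3c2)c1` differs from compound 1 by butoxy in place of bromo on an aromatic carbon. Among the compounds with values here, no measured step exchanges bromo for butoxy, so the known steps bear on this change only indirectly. The step from compound 2 to compound 3 shows that the bromo group carries much of the potency, since replacing it by fluoro costs a large step in this assay. The step from compound 1 to compound 3 shows that a further change on the same ring brings a modest loss. Removing the bromo group and inserting a butoxy chain is therefore expected to weaken inhibition in this assay by a modest to large step, a 4.1-fold higher number from compound 1 to compound 4 (0.61 log units; beyond the scatter). Compound 4 is estimated at 1800 nM, with a range from 300 nM to 10000 nM.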

Compound 4, half-maximal inhibitory concentration: > 30000 nM
Compound 4 was reported as a limit; the forecaster's own chance of this, stated with the estimate: 5%; at least 16-fold (1.22 log units) between middle value and limit.
By their numbers in this assay, from the lowest: compound 1; then compound 3; then compound 2. At a limit, above all of these: compound 4.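

Compound 4 gives no number, only a limit of the assay: the limit of > 30000 nM in this assay, at which 1 of the 4 values shown sits. Even so, the step can be read as a minimum: replacing bromo with butoxy on this aromatic carbon, meta to a large group, gives an at least 68-fold higher number from compound 1 to compound 4 (1.83 log units; beyond the scatter). The earlier compounds shown here carried only bromo or fluoro on this ring, so they could not show that butoxy at this position leaves so little measurable inhibition in this assay.

As far as these compounds go, how much weaker compound 4 really is remains unknown, since its limit gives no true value. From the compounds shown here alone, it also remains open whether a methoxy group, with its shorter chain, or a methyl group, with no oxygen, would keep more of the inhibition seen with bromo, and so whether the chain length or the oxygen matters here.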